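The compounds below may be only part of what the source reports. "The series", "measured", "known", "first", "only" and "open" are said of these compounds alone.

Measured compounds:
compound 1 `CN(C)CC(=O)NCC(=O)N(C)c1ccc(Cl)cc1C(=O)c1ccccc1Cl`, 2.6 mg/kg; compound 2 `CN(C(=O)CNC(=O)CN1CCCCC1)c1ccc(Cl)cc1C(=O)c1ccccc1Cl`, 7.5 mg/kg.

In a functional assay on the whole organism for antagonist activity, with Mus musculus as the target (a higher number here means that more compound is needed for the effect, a lower number that less compound is needed), compound 2 gives 7.5 mg/kg, the higher of the two numbers. Compound 3 `CCCCCCC(=O)NCC(=O)N(C)c1ccc(Cl)cc1C(=O)c1ccccc1Cl` differs from compound 2 in one place: pentyl in place of piperidin-1-yl on a saturated chain carbon bound to a carbonyl carbon. Among the measured compounds shown here, only one measured step bears on this change, and only loosely, since it concerns a different group on the same carbon: a 2.9-fold higher number from compound 1 to compound 2 (0.46 log units; beyond the scatter). Nothing measured shows a chain in this place. Compound 3 is therefore expected to stay near compound 2, with a wide range, estimated at 10 mg/kg between 3.5 mg/kg and 30 mg/kg, an expected step of a 1.3-fold higher number from compound 2 to compound 3 (0.12 log units; within the scatter).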

Compound 3, dose for half-maximal effect: 1.9 mg/kg
Compound 3: middle estimate off by 5.3-fold (0.72 log units), on the high side, and the stated range ends above it.
By their numbers in this assay, from the lowest: compounds 3 and 1 (each within the scatter of the next); then compound 2.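

Replacing piperidin-1-yl with pentyl on this saturated chain carbon gives a 3.9-fold lower number from compound 2 to compound 3 (0.60 log units; beyond the scatter) in this assay, so among these compounds a nitrogen in this group is not required for the effect. Pentyl in place of dimethylamino gives a 1.4-fold lower number from compound 1 to compound 3 (0.14 log units; within the scatter), so the ringless amine and the pentyl group cannot be told apart here. Nothing available explains these differences.

Still open, from the compounds shown here alone, is whether a longer chain, such as octyl, would keep this number. Also open, going by these compounds, is whether a carboxylic acid on this carbon would be tolerated.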